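The compounds below may be only part of what the source reports. "The series", "measured", "known", "first", "only" and "open" are said of these compounds alone.

Working notes on the series built on the shared core of compound 1 `C/C=C/C(=O)Nc1cccc(Oc2nc(Nc3ccc(OC)cc3)nc3c2CSCC3)c1`, read in a functional assay on HeLa cells (Homo sapiens) for antiproliferative activity, read by MTT assay, with a stated time of 72 h; on this read-out higher numbers stand for weaker inhibition and lower numbers for stronger inhibition. Compound 1 gives > 50000 nM, which is a limit of the assay and not a number. Compound 2 `CC/C=C/C(=O)Nc1cccc(Oc2nc(Nc3ccc(OC)cc3)nc3c2CSCC3)c1` gives 27200 nM. Compound 3 `CCC/C=C/C(=O)Nc1cccc(Oc2nc(Nc3ccc(OC)cc3)nc3c2CSCC3)c1` gives 12800 nM, the lower of the two actual numbers, with a 2.1-fold lower number from compound 2 to compound 3 (0.33 log units; beyond the scatter).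

Compound 4 `COc1ccc(Nc2nc3c(c(Oc4cccc(NC(=O)C=C(C)C)c4)n2)CSCC3)cc1` differs from compound 3 as follows: 2-methylprop-1-en-1-yl in place of pent-1-en-1-yl on a carbonyl carbon. In short, 2-methylprop-1-en-1-yl stands in place of pent-1-en-1-yl on a carbonyl carbon.

Going by the values given here, the steps that bear on this are the chain steps, an at least 1.8-fold lower number from compound 1 to compound 2 (0.26 log units; that floor lies within the scatter) and an at least 3.9-fold lower number from compound 1 to compound 3 (0.59 log units; beyond the scatter), along with the modest step already given. Across these three compounds the number falls as the chain lengthens, and none goes against this. Among the compounds with values here, no measured compound carries a branched chain, so that feature is untested. A modest rise in this assay is therefore expected, similar in size to the gap between compound 2 and compound 3, and a reading at the limit remains possible.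

The estimated step is a 2.1-fold higher number from compound 3 to compound 4 (0.32 log units; beyond the scatter).

For compound 4 the estimated value is 27000 nM, with an expected range of 13000 nM to 50000 nM.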

Compound 4, half-maximal inhibitory concentration: 19100 nM
Compound 4: middle estimate off by 1.4-fold (0.15 log units), on the high side, and the stated range covers the measured number.
By their numbers in this assay, from the lowest: compounds 3, 4 and 2 (each within the scatter of the next, the first and the last beyond it). At a limit, above all of these: compound 1.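

In this assay the branched 2-methylprop-1-en-1-yl on the carbonyl carbon gives a 1.5-fold higher number from compound 3 to compound 4 (0.17 log units; within the scatter) and also a 1.4-fold lower number from compound 2 to compound 4 (0.15 log units; within the scatter), so it cannot be told apart from either straight chain, pent-1-en-1-yl or but-1-en-1-yl. Branching at this place therefore shows no readable loss against these two chains, although the two chains themselves stand apart by more than the scatter. Compound 1, with prop-1-en-1-yl, reads at a limit and not a number, so an at least 2.6-fold lower number from compound 1 to compound 4 (0.41 log units; beyond the scatter) is only a floor: the limit of > 50000 nM in this assay, at which 1 of the 4 values shown sits.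

Still open, as far as these compounds go, is whether a longer chain such as hept-1-en-1-yl would continue the fall seen from compound 2 to compound 3. Also open, from the compounds shown here alone, is how a phenyl group or a dimethylamino-bearing chain would read at this carbonyl carbon.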